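Methylsulfonyl in Place of Methyl on an Amide Nitrogen

The compounds below may be only part of what the source reports. "The series", "measured", "known", "first", "only" and "open" are said of these compounds alone.

In an assay on isolated protein for inhibition of 2-Hydroxyacid oxidase 2 (Rattus norvegicus), tested at 1 uM (a lower number here means a weaker effect, a higher number a stronger effect of the compound at the concentration tested), compound 1 `Cc1n[nH]c(C(=O)O)c1Cc1ccc(C#N)cc1` gives 33%, while compound 2 `CNC(=O)c1[nH]nc(C)c1Cc1cccc(-c2ccc(F)cc2)c1` gives 9%, the lowest of the two numbers and set apart from compound 1 by a gap beyond the usual scatter. Compound 3 `Cc1n[nH]c(C(=O)NS(C)(=O)=O)c1Cc1cccc(-c2ccc(F)cc2)c1` has not yet been measured in this assay. It differs from compound 2 in one place: methylsulfonyl in place of methyl on an amide-type nitrogen. Among the measured compounds shown here, no measured pair shows this change, so the expectation rests on the two values alone: a step upward of modest size, possibly beyond the scatter. Compound 3 is expected to give 25%, between 5% and 50%. The expected step is then a number 16 percentage points higher from compound 2 to compound 3 (beyond the scatter).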

Compound 3, a percentage reported as inhibition, at one concentration (the size of the read-out at that concentration, not a potency): 0%
For compound 3 the middle estimate is 25 percentage points above the measured one; measured number below the stated range.
By their numbers in this assay, from the lowest: compounds 3 and 2 (each within the scatter of the next); then compound 1.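

In this assay, methylsulfonyl in place of methyl on the amide-type nitrogen gives a number 9 percentage points lower from compound 2 to compound 3 (within the scatter). This position therefore accepts the larger group without a read-out that can be told apart from that of the methyl group, and the change brings no gain over compound 2. Nothing measured here offers an explanation for this result. On these data alone, it remains open whether a longer chain on the sulfonyl or a hydroxyl group on the amide nitrogen would change the read-out. Compound 1 differs from compound 3 in more than one place, so it cannot settle this.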